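The compounds below may be only part of what the source reports. "The series", "measured", "known", "first", "only" and "open" are said of these compounds alone.

Measured so far:
compound 1 `Nc1ccccc1NC(=O)c1ccc(COc2ccc(Br)cc2)cc1` — > 32000 nM
compound 2 `Nc1ccccc1NC(=O)/C=C/c1ccc(CN2CCc3ccccc32)cc1` — > 32000 nM

Both values come from a functional assay on MGC-803 cells (Homo sapiens) for antiproliferative activity, read by CCK-8 assay, with a stated time of 72 h; on this read-out lower numbers stand for stronger inhibition and higher numbers for weaker inhibition. For compound 1 the figure is a limit of the assay rather than a number: compound 1 gives > 32000 nM. For compound 2 the figure is likewise a limit: compound 2 gives > 32000 nM. So compound 1 stands at the limit, and the only other value shown sits at the same limit (the limit of > 32000 nM in this assay, at which 2 of the 2 values shown sit); neither compound reaches a measurable half-maximal inhibitory concentration within the tested range.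

Compound 3 `Nc1ccccc1NC(=O)c1ccc(COc2ccc(F)cc2)cc1` is the next compound to be tested in this assay. It keeps the shared core of compound 1 and differs in a single place: fluoro in place of bromo on an aromatic carbon.

Within the data shown here, with no measured step between any two compounds, there is nothing to set the size of this change against. The expectation for compound 3 is therefore that the step that the limit leaves unreadable from compound 1 to compound 3 stays within the scatter, that is, no change beyond the usual spread. Compound 3 is expected to give about 40000 nM, within a range from 10000 nM to 160000 nM, most likely again reported only as a limit.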

Compound 3, half-maximal inhibitory concentration: 4970 nM
The estimate for compound 3 lay 8.0-fold (0.91 log units) above the measured number; measured number below the stated range.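

In this assay, fluoro in place of bromo, on an aromatic carbon para to a large group, gives an at least 6.4-fold lower number from compound 1 to compound 3 (0.80 log units; beyond the scatter), so a change of one heavy atom at this place is enough to separate two otherwise identical compounds. Of the compounds shown, compound 3 alone gives a measurable number, which means that the group at this place can decide whether the half-maximal inhibitory concentration falls within the tested range at all. From the compounds shown here alone, the true size of the step remains unknown, since the starting point for compound 1 is a limit and not a number: the limit of > 32000 nM in this assay, at which 2 of the 3 values shown sit.

Going by these compounds, with only bromo and fluoro to compare at this place, it remains open whether the gain is particular to fluoro or would also appear with chloro, methyl, methoxy or a plain hydrogen. On these data alone, it is also open whether the same exchange would have a similar effect on a different core, such as that of compound 2, or whether it holds only for the core of compound 1.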